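The source may hold more compounds than are shown below. What is called first, only, known or untested is meant among the compounds shown, and "the series" means these compounds.

Three related compounds have so far been tested in a functional assay on the whole organism (strain albino) with Rattus norvegicus as the target, in the maximal electroshock model, with a stated time of 1 h, at a dose of 30 mg/kg by the intraperitoneal route; on this read-out higher numbers stand for more inhibition at the one dose given (going by the name of the read-out) and lower numbers for less inhibition. Compound 1 `Cc1nc2ccc(Br)cc2c(=O)n1NCc1nnc(/N=C/c2ccc(N(C)C)cc2)s1` gives 50% in this assay. Compound 2 `COc1ccc(/C=N/c2nnc(CNn3c(C)nc4ccc(Br)cc4c3=O)s2)cc1` gives 50%, and compound 3 `COc1ccc(/C=N/c2nnc(CNn3c(C)nc4ccccc4c3=O)s2)cc1` gives 50%. On these numbers compound 2 stands level with both of its neighbours: the step of no change at the digits printed from compound 1 to compound 2 (within the scatter) and the step of no change at the digits printed from compound 2 to compound 3 (within the scatter) each show nothing that rises out of the scatter. Compound 4 `Cc1nc2ccc(Br)cc2c(=O)n1NCc1nnc(/N=C/c2ccccc2)s1` has not yet been measured. Its difference from compound 2 is hydrogen in place of methoxy on an aromatic carbon. Neither measured step is exactly this change, but the step of no change at the digits printed from compound 1 to compound 2 (within the scatter) alters the same group on that ring, and the step of no change at the digits printed from compound 2 to compound 3 (within the scatter) likewise replaces a substituent with hydrogen; both leave the read-out where it was. The expectation is therefore a step of no change at the digits printed from compound 2 to compound 4 (within the scatter), nothing beyond the scatter. For compound 4 the estimated value is 50%, with a range from 30% to 70%.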

Compound 4, a percentage reported as inhibition, in the whole organism at one dose (the size of the read-out at that dose, not a potency): 50%
Beside the measured number, compound 4's estimate shows no gap at the digits printed; the range from low to high includes it.
By their numbers in this assay, from the lowest: compounds 1, 2, 3 and 4 (each within the scatter of the next).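

Taking the methoxy away and leaving hydrogen on that aromatic carbon gives no change at the digits printed from compound 2 to compound 4 (within the scatter) in this assay, and taking the dimethylamino away gives no change at the digits printed from compound 1 to compound 4 (within the scatter). The position para to a large group has now been read bare as well as with either of these two groups, and among these compounds a substituent there is not needed to hold the read-out at this one dose. Nothing measured here accounts for this flat result.

Open, on these data alone, is whether a carboxylic acid, a chloro group or a longer chain such as butoxy at this position would shift the read-out. A reading at one dose is also not a potency, so these compounds could still differ from one another at other doses.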